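Nitro to methoxy on the phenyl ring of compound 1

The source may hold more compounds than are shown below. What is called first, only, known or untested is meant among the compounds shown, and "the series" means these compounds.

Among the measured compounds shown here, compound 1 `O=c1c2cc([N+](=O)[O-])cnc2sn1-c1ccc([N+](=O)[O-])cc1` is measured in an assay for inhibition of histone acetyltransferase KAT2B (Homo sapiens), read by fluorescence (on this read-out higher numbers stand for weaker inhibition and lower numbers for stronger inhibition), at 15800 nM, the higher of the two numbers so far; compound 2 `O=c1c2cccnc2sn1-c1ccc([N+](=O)[O-])cc1` gives 2990 nM. For the measured compounds named here, the only step known, a 5.3-fold lower number from compound 1 to compound 2 (0.72 log units; beyond the scatter), concerns the core, not the phenyl ring. Compound 3 `COc1ccc(-n2sc3ncc([N+](=O)[O-])cc3c2=O)cc1` differs from compound 1 by methoxy in place of nitro on an aromatic carbon. Going by the values given here, no measured step bears directly on this change, so the expectation is a small shift, likely within the scatter, with the direction uncertain. Compound 3 is therefore expected to show a 1.3-fold lower number from compound 1 to compound 3 (0.12 log units; within the scatter), with an estimate of 12000 nM in the range 3000 nM to 40000 nM.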

Compound 3, half-maximal inhibitory concentration: 1830 nM
Compound 3: the middle estimate sits 6.6-fold (0.82 log units) above what was measured; measured number below the stated range.
By their numbers in this assay, from the lowest: compounds 3 and 2 (each within the scatter of the next); then compound 1.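

Methoxy in place of nitro on the phenyl ring, para to a large group, gives an 8.6-fold lower number from compound 1 to compound 3 (0.94 log units; beyond the scatter) in this assay, so this position responds to substitution. With a 5.3-fold lower number from compound 1 to compound 2 (0.72 log units; beyond the scatter), replacing nitro at either of two places on compound 1 lowers the number. No available data bear on why the number falls.

On these data alone, whether this step reflects methoxy itself or the loss of nitro stays open, and a hydrogen, an amine or chlorine at this position would help separate the two. Also open, as far as these compounds go, is whether methoxy lowers the number on the core of compound 2.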